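A few compounds are considered here, and "the series" means these few. Any claim that something is new, unique, unknown or untested is made for them only; others in the source may bear on it.

Measured so far in a functional assay on the whole organism with Rattus norvegicus as the target, at a dose of 25 mg/kg by the intravenous route; a lower number here means that less compound is needed, a higher number that more compound is needed for the effect:
Compound 1 `CCCCc1ccc(C(=O)Nc2cc(C(=O)O)cc(C(=O)O)c2)cc1`: 12.3 mg/kg
Compound 2 `O=C(O)c1cc(NC(=O)c2ccc(-c3nn[nH]n3)cc2)cc(C(=O)O)c1`: 1.2 mg/kg

Compound 2 has the lower of these two numbers, so less of it is needed for the effect. Putting 2H-tetrazol-5-yl in place of butyl on an aromatic carbon gave a 10-fold lower number from compound 1 to compound 2 (1.01 log units; beyond the scatter), a large step beyond the usual scatter.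

Compound 3 `O=C(O)c1ccc(C(=O)Nc2cc(C(=O)O)cc(C(=O)O)c2)cc1` keeps the shared core and replaces that same group: carboxy in place of 2H-tetrazol-5-yl on an aromatic carbon, para to a large group (carboxy in place of 2H-tetrazol-5-yl on an aromatic carbon).

Among the compounds with values here, only one measured step bears on this change, and it is an indirect guide. a 10-fold lower number from compound 1 to compound 2 (1.01 log units; beyond the scatter) shows that the group at this place can matter in this assay, but that step started from butyl, and no measured compound carries the entering group. The count shows the two groups alike in hydrogen-bond donors, so a much smaller step is expected here, with a slight move towards a higher number.

The estimated change is a 1.7-fold higher number from compound 2 to compound 3 (0.22 log units; within the scatter), which may not exceed the scatter. For compound 3 the expected value is 2 mg/kg, with an estimated range of 0.6 mg/kg to 7 mg/kg.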

Compound 3, dose for 50% inhibition: 2.1 mg/kg
The estimate for compound 3 lay 1.1-fold (0.02 log units) below the measured number; the range from low to high includes it.
By their numbers in this assay, from the lowest: compounds 2 and 3 (each within the scatter of the next); then compound 1.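

Replacing 2H-tetrazol-5-yl with carboxy gives a 1.8-fold higher number from compound 2 to compound 3 (0.24 log units; within the scatter) in this assay, so this assay cannot tell these two groups apart at this position, even though carboxy has fewer heavy atoms and no ring. The earlier drop in the number on leaving butyl therefore does not need the tetrazole ring: carboxy in place of butyl also gives a 5.9-fold lower number from compound 1 to compound 3 (0.77 log units; beyond the scatter), a modest step that lies beyond the scatter. No measurement shown explains why butyl differs from these two groups.

The compounds shown leave open how a methyl ester, an amine or a hydroxyl group would compare at this same position, and whether a chain shorter than butyl would behave like butyl. They also leave open what the two carboxy groups on the shared core contribute, as all three compounds carry both of them unchanged.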